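The source may report more compounds than this note shows. Statements on the series, on what has been measured and on what is new or still open speak of the compounds shown alone.

Measured so far in a toxicity assay on THP-1 cells (Homo sapiens) for inhibition; on this read-out higher numbers stand for lower toxicity in this test and lower numbers for higher toxicity in this test:

Compound 1 `COc1ccc(C(=O)Nc2ncc(-c3ccc(OC)cc3)n2C)cc1` gives > 100000 nM, which is a limit of the assay rather than a number.
Compound 2 `COc1ccc(-c2cnc(NC(=O)c3cnco3)n2C)cc1` gives > 100000 nM, also a limit of the assay.

Compound 2 thus stands at the top of what this assay can report, and compound 1 sits there as well (the limit of > 100000 nM in this assay, at which 2 of the 2 values shown sit). Within the data shown here, the one measured step, a step that the two limits leave unreadable from compound 1 to compound 2, is unreadable for the same reason, so it gives no size in either direction.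

Compound 3 `COc1ccc(-c2cnc(NC(=O)c3ccc(C#N)cc3)n2C)cc1` differs from compound 2 by 4-cyanophenyl in place of 1,3-oxazol-5-yl on a carbonyl carbon. Among the measured compounds shown here, the only measured step touches the same carbonyl carbon, and it left both compounds at the limit, so no shift beyond the scatter is expected for compound 3; its expected step is a number no higher from compound 2 to compound 3 (the limit leaves the size open). Compound 3 is therefore estimated at 100000 nM, within a range from 30000 nM to 300000 nM, most likely again reported only as a limit.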

Compound 3, half-maximal cytotoxic concentration: > 100000 nM
Compound 3: only a limit was reported; the forecaster's own chance of this, stated with the estimate: 75%; the middle value lies on the limit itself.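

Compound 3 is reported only as a limit of the assay, as are compound 1 and compound 2, so none of the steps among these compounds can be read. Going by these compounds, how far each compound lies beyond that limit in this assay remains open.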